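Compound 3 to compound 4: a carboxy group enters

The source may report more compounds than this note shows. Statements on the series, on what has been measured and on what is new or still open speak of the compounds shown alone.

Measured in a functional assay on MCF7 cells (Homo sapiens) for antiproliferative activity, read by MTT assay, with a stated time of 72 h; on this read-out lower numbers stand for stronger inhibition and higher numbers for weaker inhibition:
- Compound 1 `CCn1c(C(=O)NCc2ccc(OC)cc2)ccc1C(CC)(CC)c1ccc(C#CC(O)(CC)CC)c(C)c1`: > 50000 nM (a limit of the assay, not a number)
- Compound 2 `CCn1c(C(=O)N[C@H](C(=O)O)C(C)C)ccc1C(CC)(CC)c1ccc(C#CC(O)(CC)CC)c(C)c1`: 13000 nM
- Compound 3 `CCN(CC)CCNC(=O)c1cc(C(CC)(CC)c2ccc(C#CC(O)(CC)CC)c(C)c2)cn1CC`: 1800 nM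

Compound 3 has the lowest number shown, and the nearest number belongs to compound 2. Compound 4 `CCn1cc(C(CC)(CC)c2ccc(C#CC(O)(CC)CC)c(C)c2)cc1C(=O)NCC(=O)O` alters the side chain of compound 3: carboxy in place of (diethylamino)methyl on a saturated chain carbon bound to an amide-type nitrogen.

For the measured compounds named here, one measured step bears on this: an at least 3.8-fold lower number from compound 1 to compound 2 (0.58 log units; beyond the scatter), with 1-carboxy-2-methylpropyl in place of 4-methoxybenzyl on an amide-type nitrogen. Its starting value is a limit. The closest guide is compound 2, which also has a carboxy group on its amide side chain and gives 13000 nM. A move to a higher number, beyond the scatter, is therefore expected in this assay. The expected change is a 5.0-fold higher number from compound 3 to compound 4 (0.70 log units; beyond the scatter). Compound 4 is estimated at 9000 nM, with an expected range of 2500 nM to 35000 nM.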

Compound 4, half-maximal inhibitory concentration: 17500 nM
Estimate against measurement, compound 4: 1.9-fold (0.29 log units) below, and the stated range covers the measured number.
By their numbers in this assay, from the lowest: compound 3; then compounds 2 and 4 (each within the scatter of the next). At a limit, above all of these: compound 1.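

In this assay, the end of the amide side chain clearly matters: carboxy in place of (diethylamino)methyl gives a 9.7-fold higher number from compound 3 to compound 4 (0.99 log units; beyond the scatter). The carboxy group therefore does not lower the number in every setting, even though an at least 3.8-fold lower number from compound 1 to compound 2 (0.58 log units; beyond the scatter) came with a carboxy-bearing side chain and started from a limit. No measurement shown gives a cause for the rise.

Still open, as far as these compounds go, is whether a shorter amine such as dimethylamino would hold the lower number of compound 3. A longer chain ending in a carboxylic acid also remains untested among these compounds.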